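The source may hold more compounds than are shown below. What is called first, only, known or untested is meant among the compounds shown, and "the series" means these compounds.

Measured compounds in an ADME assay on MRC5 cells (Homo sapiens) for cytotoxicity, with a stated time of 48 h; a higher number here means a weaker inhibitor, a lower number a stronger inhibitor:

Compound 1, `OC[C@@H]1[C@@H](O)[C@@H](O)CN1Cc1cccc2cccnc12`: > 64000 nM.
Compound 2, `O=c1[nH]cnc2c(CN3C[C@H](O)[C@H](O)[C@H]3CO)csc12`: > 64000 nM.
Compound 3, `Nc1nc2c(CN3C[C@H](O)[C@H](O)[C@H]3CO)cccc2s1`: > 64000 nM.

Compound 1 stands at the limit of this assay: its value of > 64000 nM is a limit and not a number. The same holds for compound 2, whose > 64000 nM is a limit. Compound 3 likewise shows a limit with > 64000 nM. Among the measured compounds shown here, nothing separates the three; (the limit of > 64000 nM in this assay, at which 3 of the 3 values shown sit), so no ranking among them is possible, and the series so far is uniformly inactive in this assay.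

Compound 4, `COc1ccnc2c(CN3C[C@H](O)[C@H](O)[C@H]3CO)cccc12`, differs from compound 1 by a single change: methoxy in place of hydrogen on an aromatic carbon. For the measured compounds named here, no measured step between two compounds is available, so the expectation for this change rests only on the three limits seen.

Given that compound 1 sits at > 64000 nM, the step that the limit leaves unreadable from compound 1 to compound 4 is expected to be none beyond the scatter. Compound 4 is therefore expected to give 100000 nM, with a range from 50000 nM to 200000 nM, most likely reported again as a limit rather than a number.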

Compound 4, half-maximal inhibitory concentration: > 64000 nM
Compound 4 gave a limit, no number; the forecaster's own chance of this, stated with the estimate: 90%; the middle value does not contradict the limit.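

In this assay the step from compound 1 to compound 4 cannot be read, because both values are limits and not numbers: the limit of > 64000 nM in this assay, at which 4 of the 4 values shown sit. The compounds shown leave open whether any change to the shared core would give a measurable value in this assay at all.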